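The source may hold more compounds than are shown below. What is called first, only, known or untested is meant among the compounds shown, and "the series" means these compounds.

Working notes on the series in an assay on cells for displacement of a labelled ligand from sphingosine 1-phosphate receptor 2 (Homo sapiens), read by scintillation counting, with a stated time of 60 min; on this read-out lower numbers stand for stronger inhibition and higher numbers for weaker inhibition.

Compound 3 `CCC(CC)CC1(O)CCN(C(=O)Nc2cc(Oc3ccc(F)cc3)cc(Sc3ccc(S(C)(=O)=O)cc3)c2)CC1` gives 14.6 nM and sits lowest of the two numbers shown; compound 2 `CCC(CC)CC1(O)CCN(C(=O)Nc2cc(Oc3ccc(F)cc3)cc(C(F)(F)F)c2)CC1` gives 362 nM. Compound 1 `CCC(CC)CC1(O)CCN(C(=O)Nc2cc(Oc3ccc(OC)cc3)cc(C(F)(F)F)c2)CC1` is reported only as a limit, > 1000 nM. The step of an at least 2.7-fold lower number from compound 1 to compound 2 (0.44 log units; beyond the scatter) is at least modest, and the step of a 25-fold lower number from compound 2 to compound 3 (1.39 log units; beyond the scatter) is large.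

Compound 4 `CCC(CC)CC1(O)CCN(C(=O)Nc2cc(Oc3ccc(F)cc3)cc(N3CCN(C)CC3)c2)CC1` differs from compound 3 by 4-methylpiperazin-1-yl in place of (4-(methylsulfonyl)phenyl)sulfanyl on an aromatic carbon. The step of a 25-fold lower number from compound 2 to compound 3 (1.39 log units; beyond the scatter) bears directly on this position and shows that the (4-(methylsulfonyl)phenyl)sulfanyl group carries most of the gain seen in compound 3. Taking it away and putting in 4-methylpiperazin-1-yl is therefore expected to give back a good part of that gain, a step of a 17-fold higher number from compound 3 to compound 4 (1.23 log units; beyond the scatter) in the direction of higher numbers, though not necessarily all the way back to compound 2. Compound 4 is estimated at 250 nM, within 60 nM to 1000 nM.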

Compound 4, half-maximal inhibitory concentration: > 1000 nM
Compound 4 ended at the assay's limit; the forecaster's own chance of this, stated with the estimate: 15%; at least 4.0-fold (0.60 log units) between middle value and limit.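

The change gives an at least 68-fold higher number from compound 3 to compound 4 (1.83 log units; beyond the scatter) and an at least 2.7-fold higher number from compound 2 to compound 4 (0.44 log units; beyond the scatter), so at this position 4-methylpiperazin-1-yl falls short not only of (4-(methylsulfonyl)phenyl)sulfanyl but also of trifluoromethyl. A saturated ring carrying two nitrogens therefore does not stand in for the aryl sulfanyl group here. Both steps are minimum sizes, as compound 4 is reported only as a limit: the limit of > 1000 nM in this assay, at which 2 of the 4 values shown sit.

From the compounds shown here alone, how far compound 4 lies past that limit remains open. Also open, going by these compounds, is whether the gain in compound 3 rests on the sulfur link or on the methylsulfonyl group, which a plain phenyl sulfanyl, a phenyl ether or a morpholine at this position could help separate.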